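Swapping the Outer Group on Compound 2

The compounds below may be only part of what the source reports. "The series", "measured", "known", "first", "only" and "open" are said of these compounds alone.

In a physicochemical assay for lipophilicity, read by HPLC, at pH 7.5 (a higher number here means a more lipophilic compound, a lower number a more polar compound), compound 2 `CC[C@@H](Nc1c(C#N)c(-c2ccc(-c3cccc(Cl)c3F)cc2)nc2cnccc12)C(N)=O` gives 3.1 and sits within the scatter of compound 1 `CC[C@@H](Nc1c(C#N)c(-c2ccc(-c3cccc(C)c3)cc2)nc2cnccc12)C(N)=O` at 3 while compound 3 `CC[C@@H](Nc1c(C#N)c(-c2ccc(Br)cc2)nc2cnccc12)C(=O)O` at 1.6 lies well lower, beyond the scatter. Compound 4 `CC[C@@H](Nc1c(C#N)c(-c2ccc(-c3ccccc3COC)cc2)nc2cnccc12)C(N)=O` has not been measured yet, and its change is 2-(methoxymethyl)phenyl in place of 3-chloro-2-fluorophenyl on an aromatic carbon with a hydrogen-bond acceptor arriving in the new group. Among the compounds with values here, the one measured step that bears on this is a number 0.10 log units higher from compound 1 to compound 2 (within the scatter) and it stayed within the scatter, but it brought in no such acceptor, which leaves it a weak guide. A modest fall is expected, so the estimated move is a number 0.30 log units lower from compound 2 to compound 4 (within the scatter) in this assay with wide margins. Compound 4 is expected to read 2.8 with an estimated range from 2.4 to 3.2 for now.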

Compound 4, distribution coefficient: 2.6
Compound 4: the middle estimate sits 0.20 log units above what was measured; the range from low to high includes it.
By their numbers in this assay, from the lowest: compound 3; then compound 4; then compounds 1 and 2 (each within the scatter of the next).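

At this position, on an aromatic carbon para to a large group, the choice of outer ring can shift this assay beyond the scatter: 2-(methoxymethyl)phenyl gives a number 0.50 log units lower from compound 2 to compound 4 (beyond the scatter) and a number 0.40 log units lower from compound 1 to compound 4 (beyond the scatter). The two earlier rings, 3-methylphenyl and 3-chloro-2-fluorophenyl, stayed within the scatter of each other, so this change shows something their comparison could not. No measurement shown explains the shift.

Still open, on these data alone, is whether the oxygen of the new group matters, which a plain propyl chain on the same ring could test. How an amine there would read is also unknown.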